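Changing the sulfur-bearing arm of compound 2

The source may hold more compounds than are shown below. What is called first, only, known or untested is meant among the compounds shown, and "the series" means these compounds.

Of the compounds shown here, two have been measured in a functional assay on DU-145 cells (Homo sapiens) for inhibition, read by trypan blue exclusion, with a stated time of 96 h; a higher number here means a weaker inhibitor of growth, a lower number a stronger inhibitor of growth. Compound 1 `COc1ccc(/C=C(\C(=O)c2ccc(Cl)cc2)S(=O)(=O)Cc2ccccc2Cl)cc1` gives 50000 nM, and compound 2 `CCOc1ccc(/C=C(\C(=O)c2ccc(Cl)cc2)S(=O)(=O)Cc2ccccc2Cl)cc1OC` gives 10000 nM. Going by the values given here, the single measured step, a 5.0-fold lower number from compound 1 to compound 2 (0.70 log units; beyond the scatter), shows that altering the aromatic ring at one end of the chain can move the number well beyond the scatter. Compound 2 therefore stands at the lowest of the two numbers, set apart from compound 1 by that step.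

Compound 3 `CCOc1ccc(/C=C(/SCc2ccc(F)cc2)C(=O)c2ccc(Cl)cc2)cc1OC` has not yet been measured. It differs from compound 2 by (4-fluorobenzyl)sulfanyl in place of (2-chlorobenzyl)sulfonyl on a double-bonded chain carbon bound to a carbonyl carbon and a double-bonded chain carbon. Among the compounds with values here, no measured step touches this part of the molecule: the only step available, a 5.0-fold lower number from compound 1 to compound 2 (0.70 log units; beyond the scatter), concerns a different position, so it says nothing about the direction of the new change. Two things move at once here, the sulfonyl becoming a sulfanyl and one halogenated benzyl giving way to another, which makes the outcome hard to call. Compound 3 is expected to give about 10000 nM in this assay, with a range from 2000 nM to 50000 nM. The expected step of no change at the digits printed from compound 2 to compound 3 (within the scatter) is thus estimated to stay within the scatter, though wide uncertainty remains.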

Compound 3, concentration for 50% growth inhibition: 1000 nM
Compound 3: middle estimate off by 10-fold (1.00 log units), on the high side; the measured number lies below the stated range.
By their numbers in this assay, from the lowest: compound 3; then compound 2; then compound 1.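

In this assay, the step of a 10-fold lower number from compound 2 to compound 3 (1.00 log units; beyond the scatter) shows that the sulfur-bearing arm, on the double-bonded chain carbon bound to a carbonyl carbon and a double-bonded chain carbon, can also move the number beyond the scatter; until now, only a change to the aromatic ring at the other end of the chain had been seen to do so. The swap bundles two edits, since sulfonyl becomes sulfanyl while 2-chlorobenzyl gives way to 4-fluorobenzyl, so this step belongs to the pair of edits taken together and cannot be assigned to either one alone. Nothing given here offers a measured explanation for the step.

The compounds shown leave open how much of the step comes from the sulfur and how much from the halogenated benzyl, a question that a (2-chlorobenzyl)sulfanyl or (4-fluorobenzyl)sulfonyl arm on the same core would help to settle. Also open, going by these compounds, is how this assay would read with an amine in place of the sulfur, or with a longer chain linking the sulfur to the ring.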